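Extending the methyl to propyl in a guanidine-acyl series

The source may hold more compounds than are shown below. What is called first, only, known or untested is meant among the compounds shown, and "the series" means these compounds.

Compound 3 `Cc1cc(C)c(S(C)(=O)=O)cc1C(=O)N=C(N)N` gives, in a functional assay for inhibition of sodium/hydrogen exchanger (Oryctolagus cuniculus) (on this read-out lower numbers stand for stronger inhibition and higher numbers for weaker inhibition), 11 nM, the lowest number among the three measured compounds; the step of a 1.1-fold lower number from compound 2 to compound 3 (0.04 log units; within the scatter) is within the scatter, so compound 2 `Cc1cc(Br)c(S(C)(=O)=O)cc1C(=O)N=C(N)N` with 12 nM cannot be set apart from it, while compound 1 `Cc1cc(Cl)c(S(C)(=O)=O)cc1C(=O)N=C(N)N` with 25 nM lies further off, as the step of a 2.3-fold lower number from compound 1 to compound 3 (0.36 log units; beyond the scatter) shows. Compound 4 `CCCc1cc(C)c(C(=O)N=C(N)N)cc1S(C)(=O)=O` differs from compound 3 by ethyl in place of hydrogen on a saturated chain carbon bound to an aromatic carbon. Going by the values given here, none of the measured steps touches this kind of change: the steps of a 2.1-fold lower number from compound 1 to compound 2 (0.32 log units; beyond the scatter) and a 2.3-fold lower number from compound 1 to compound 3 (0.36 log units; beyond the scatter) swap one group for another on an aromatic carbon, and a 1.1-fold lower number from compound 2 to compound 3 (0.04 log units; within the scatter) does the same. They only show that the shared core tolerates modest variation at that aromatic position without a large swing. Among the compounds with values here, for the chain extension in compound 4 there is no precedent here, so the expectation is a step of no size beyond the scatter, a 1.3-fold higher number from compound 3 to compound 4 (0.10 log units; within the scatter). Compound 4 is therefore estimated at 14 nM in this assay, with a range from 5 nM to 40 nM.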

Compound 4, half-maximal inhibitory concentration: 5.7 nM
The estimate for compound 4 lay 2.5-fold (0.39 log units) above the measured number; the measured number falls inside the stated range.
By their numbers in this assay, from the lowest: compounds 4, 3 and 2 (each within the scatter of the next, the first and the last beyond it); then compound 1.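

In this assay, going by these compounds alone, extending methyl to propyl gives a 1.9-fold lower number from compound 3 to compound 4 (0.29 log units; within the scatter), so this place accepts a chain longer than the earlier compounds carried, and the number for the propyl compound cannot be set apart from that for the methyl compound. The propyl group in place of a halogen on the same aromatic carbon gives a 2.1-fold lower number from compound 2 to compound 4 (0.32 log units; beyond the scatter) and a 4.4-fold lower number from compound 1 to compound 4 (0.64 log units; beyond the scatter), both beyond the scatter, so the propyl compound separates from the chloro and bromo compounds, whereas the methyl compound separates only from the chloro compound. Nothing available gives a reason for these steps.

The compounds shown leave open how far this tolerance extends, whether to a longer chain such as pentyl or to a branched one such as isopropyl. They also leave open whether a chain ending in an amine or a carboxylic acid would be accepted at this place.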